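Methyl to methylcarbamoyl triazole: solubility notes

The source may hold more compounds than are shown below. What is called first, only, known or untested is meant among the compounds shown, and "the series" means these compounds.

In a physicochemical assay for solubility, at pH 6.8 (on this read-out higher numbers stand for higher solubility and lower numbers for lower solubility), compound 1 `Cc1ccc(NC(=O)C2CCN(c3ncccc3Cl)CC2)cc1Cl` gives < 4000 nM, which is a limit and not a number. Within the data shown here, compound 2 `Cc1nc(C)n(-c2ccc(NC(=O)C3CCN(c4ncccc4[N+](=O)[O-])CC3)cc2Cl)n1` gives 7000 nM, the only true number so far. Compound 3 `CNC(=O)c1ncn(-c2ccc(NC(=O)C3CCN(c4ncccc4Cl)CC3)cc2Cl)n1` has 3-(methylcarbamoyl)-1H-1,2,4-triazol-1-yl in place of methyl on an aromatic carbon, ortho to a chloro group: 3-(methylcarbamoyl)-1H-1,2,4-triazol-1-yl in place of methyl on an aromatic carbon. Among the measured compounds shown here, no measured single-place step exists to size this change. For the measured compounds named here, with compound 2 at 7000 nM as the sole guide, a modest rise in this assay is expected. The expected step is an at least 1.2-fold higher number from compound 1 to compound 3 (0.09 log units; that floor lies within the scatter). The estimate for compound 3 is 5000 nM, with an expected range of 2000 nM to 15000 nM.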

Compound 3, solubility: < 4000 nM
Compound 3 was reported as a limit; the forecaster's own chance of this, stated with the estimate: 35%; middle value at least 1.2-fold (0.09 log units) away from the limit.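

No step can be read from compound 1 to compound 3, because both stop at a limit in this assay: the limit of < 4000 nM in this assay, at which 2 of the 3 values shown sit. Open, from the compounds shown here alone, is how 3-(methylcarbamoyl)-1H-1,2,4-triazol-1-yl in place of methyl moves this read-out, in size or in direction.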